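This account rests on a few compounds, and the source may have more. Where it says the series, first, only, none or still open, it means among the compounds named here.

Compound 1, `CCCCOC(=O)CNC(=O)[C@H](CSc1ccc([N+](=O)[O-])cc1[N+](=O)[O-])NC(=O)CC[C@H](NC(=O)CCc1c[nH]c2ccccc12)C(=O)OCCCC`, gives 26 uM in a toxicity assay on KB cells (Homo sapiens) for cytotoxicity, read by fluorescence, with a stated time of 3 days; on this read-out higher numbers stand for an effect only at larger amounts of compound and lower numbers for an effect already at smaller amounts. Compound 2, `CCCCOC(=O)CNC(=O)[C@H](CSc1ccc([N+](=O)[O-])cc1[N+](=O)[O-])NC(=O)CC[C@H](NC(=O)COc1ccccc1)C(=O)OCCCC`, gives > 300 uM in this assay, and this is a limit of the assay, not a number. Compound 2 thus stands at the limit of > 300 uM in this assay, at which 1 of the 2 values shown sits.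

Among the compounds with values here, the only measured step is an at least 11-fold higher number from compound 1 to compound 2 (1.06 log units; beyond the scatter), which is large and beyond the scatter. It falls on a saturated chain carbon bound to a carbonyl carbon, the same place that changes next. Compound 3, `CCCCCCCCCCCCCC(=O)N[C@@H](CCC(=O)N[C@@H](CSc1ccc([N+](=O)[O-])cc1[N+](=O)[O-])C(=O)NCC(=O)OCCCC)C(=O)OCCCC`, differs from compound 2 as follows: dodecyl in place of phenoxy on a saturated chain carbon bound to a carbonyl carbon. In words, dodecyl stands in place of phenoxy. Within the data shown here, no measured step covers a long chain at this place, so the expectation rests on a single indirect comparison. That comparison, an at least 11-fold higher number from compound 1 to compound 2 (1.06 log units; beyond the scatter), shows that the group held here can shift the read-out by a large amount. A large move towards a lower number is therefore expected, though compound 3 could also stay at the limit. The estimated change is an at least 7.5-fold lower number from compound 2 to compound 3 (0.87 log units; beyond the scatter). For compound 3 the expected value is 40 uM. The estimated range for compound 3 runs from 10 uM to 200 uM.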

Compound 3, concentration for half-maximal effect: > 300 uM
Compound 3 was reported as a limit; the forecaster's own chance of this, stated with the estimate: 20%; middle value at least 7.5-fold (0.87 log units) from the limit.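

At this position a long open chain behaves like phenoxy, not like the group of compound 1. In this assay the change to undecyl in place of 1H-indol-3-yl is an at least 11-fold higher number from compound 1 to compound 3 (1.06 log units; beyond the scatter), and this large step ends at a limit of the assay, as the step of an at least 11-fold higher number from compound 1 to compound 2 (1.06 log units; beyond the scatter) does. Two very different groups, one with a six-membered aromatic ring and one with no ring, thus both leave the read-out at the limit, and among the compounds shown only compound 1 gives a readable number: the limit of > 300 uM in this assay, at which 2 of the 3 values shown sit. The step between compound 2 and compound 3 cannot be read, as both values are limits, so nothing places phenoxy and dodecyl in order.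

From the compounds shown here alone, whether the readable number of compound 1 depends on the 1H-indol-3-yl group itself or would also appear with another ring system, such as a naphthyl or an imidazolyl group on the same chain, stays open. Going by these compounds, how an amine or a carboxylic acid at this place would read in this assay also stays open.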